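The source may hold more compounds than are shown below. What is called first, only, known or untested is meant among the compounds shown, and "the series" means these compounds.

Measured compounds:
compound 1 `COc1cc(-c2nn(-c3cccc(NC(=O)Nc4cc(C(F)(F)F)cc(C(F)(F)F)c4)c3)cc2-c2ccncc2)ccc1Cl`, 916 nM
compound 2 `COc1cc(-c2nn(-c3cccc(NC(=O)c4cccc(C(F)(F)F)c4)c3)cc2-c2ccncc2)ccc1Cl`, 27900 nM
compound 3 `O=C(Nc1cccc(-n2cc(-c3ccncc3)c(-c3ccc(Cl)c(O)c3)n2)c1)Nc1cc(C(F)(F)F)cc(C(F)(F)F)c1`, 965 nM

In a functional assay on UACC-257 cells (Homo sapiens) for inhibition, read by sulforhodamine B assay, with a stated time of 48 h (a higher number here means a weaker inhibitor of growth, a lower number a stronger inhibitor of growth), compound 2 stands at the highest number of the three. Its nearest neighbour is compound 3, which gives 965 nM, and the gap to compound 1, at 916 nM, is slightly wider still; both gaps lie well beyond the scatter, so compound 2 is the weakest inhibitor of growth among the measured set.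

Compound 4 `COc1cc(-c2nn(-c3cccc(NC(=O)c4ccccc4)c3)cc2-c2ccncc2)ccc1Cl` is compound 2 with one change: hydrogen in place of trifluoromethyl on an aromatic carbon. It has not yet been tested in this assay.

Within the data shown here, no measured step tracks this change. Among the measured compounds shown here, the only single-point step available, a 1.1-fold higher number from compound 1 to compound 3 (0.02 log units; within the scatter), concerns a methyl replaced by hydrogen on an oxygen elsewhere in the molecule and sits within the scatter; it says nothing about the carbon that carries the trifluoromethyl. For the measured compounds named here, compounds 1 and 3 differ from compound 2 in more than one place, so their values show only that compound 2 is far weaker than both. With nothing to guide the direction, the step from compound 2 to compound 4 is expected to be small, a 1.3-fold higher number from compound 2 to compound 4 (0.10 log units; within the scatter), and most likely within the scatter. Compound 4 is therefore estimated at 35000 nM, with a range from 12000 nM to 100000 nM.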

Compound 4, concentration for 50% growth inhibition: 859 nM
Compound 4: the middle estimate sits 41-fold (1.61 log units) above what was measured; measured number outside the range, below it.
By their numbers in this assay, from the lowest: compounds 4, 1 and 3 (each within the scatter of the next); then compound 2.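

The change from 3-(trifluoromethyl)phenyl to phenyl gives a 32-fold lower number from compound 2 to compound 4 (1.51 log units; beyond the scatter) in this assay, so this aromatic carbon is a place where the read-out responds strongly, and here the loss of trifluoromethyl goes with a much stronger inhibitor of growth. The only earlier step between compounds differing in one place, a 1.1-fold higher number from compound 1 to compound 3 (0.02 log units; within the scatter), concerned a methyl on an oxygen and showed no change beyond the scatter, so this is the first single change shown to move the number by a wide margin. No measured property of these compounds accompanies the result, and the size of the step therefore remains unexplained.

The compounds shown leave open whether this step belongs to trifluoromethyl in particular or to any group on this carbon, a question that a methyl, a chlorine or a methoxy group there could settle. They also leave open whether removing trifluoromethyl from compound 1 or compound 3 would bring a step of similar size and direction.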